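Methyl and chloro on the two aryl rings: series notes

This account rests on a few compounds, and the source may have more. Where it says the series, first, only, none or still open, it means among the compounds named here.

Measured so far:
Compound 1 `CC(C)(C)NCc1c(C(=O)O)nn(-c2ccccc2)c1-c1ccccc1` gives > 716000 nM, a limit of the assay.
Compound 2 `Cc1ccc(-c2c(CNC(C)(C)C)c(C(=O)O)nn2-c2ccccc2)cc1` gives > 688000 nM, a limit of the assay.
Going by the values given here, compound 3 `CC(C)(C)NCc1c(C(=O)O)nn(-c2ccc(Cl)cc2)c1-c1ccccc1` gives 496000 nM, the only number among the three.

The read-out is a functional assay on MCF7 cells (Homo sapiens) for inhibition, read by sulforhodamine B assay, with a stated time of 48 h; on this read-out higher numbers stand for weaker inhibition of growth and lower numbers for stronger inhibition of growth. Compound 4 `Cc1ccc(-c2c(CNC(C)(C)C)c(C(=O)O)nn2-c2ccc(Cl)cc2)cc1` is not yet measured in this assay.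

Compound 2 differs from compound 1 by methyl in place of hydrogen on an aromatic carbon. The step that the two limits leave unreadable from compound 1 to compound 2 cannot be sized. Compound 1 sits at the limit of > 716000 nM in this assay, at which 1 of the 3 values shown sits. Compound 2 sits at the limit of > 688000 nM in this assay, at which 1 of the 3 values shown sits.

Compound 4 carries the same change against compound 3, (methyl in place of hydrogen on an aromatic carbon); the place is the same in both pairs. Among the compounds with values here, the two cores differ by chloro in place of hydrogen on an aromatic carbon, with an at least 1.4-fold lower number from compound 1 to compound 3 (0.15 log units; that floor lies within the scatter) as the only sized step in the set, and that floor lies within the usual scatter.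

The change from compound 3 is expected to give a step of about a 1.1-fold higher number from compound 3 to compound 4 (0.04 log units; within the scatter), resting on the unreadable a step that the two limits leave unreadable from compound 1 to compound 2, which offers no sign of a gain from this methyl. Compound 4 is estimated at 550000 nM, within 250000 nM to 1000000 nM, with a real chance that this assay again reports only a limit.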

Compound 4, concentration for 50% growth inhibition: > 629000 nM
Compound 4 ended at the assay's limit; the forecaster's own chance of this, stated with the estimate: 45%; at least 1.1-fold (0.05 log units) between middle value and limit.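

In this assay, methyl in place of hydrogen on the core of compound 3 gives an at least 1.2-fold higher number from compound 3 to compound 4 (0.10 log units; that floor lies within the scatter), so the phenyl to 4-methylphenyl change offers no sign of a gain in growth inhibition on this core, though the floor of that step does not establish a loss. Going by these compounds, compound 4 gives > 629000 nM, which is a limit of the assay, so the true size of the step remains unknown. The steps from compound 1 to compound 2 and from compound 2 to compound 4 cannot be read, which means the series shows no sized effect of this methyl on the core of compound 1 and cannot show whether the change carries over with the same size.

The compounds shown leave open what a methyl ester or a primary amide in place of the carboxylic acid would do in this assay. Also open, on these data alone, is whether methoxy or fluoro on either aryl ring would give a readable number, as chloro does in compound 3.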